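A few compounds are considered here, and "the series" means these few. Any claim that something is new, unique, unknown or untested is made for them only; others in the source may bear on it.

Measured in an ADME assay on a cell-free system (plasma, Homo sapiens) for protein binding:
- Compound 1 `CCNc1nccc(N2CC[C@H](NC(=O)Nc3ccc(Cl)c(C(F)(F)F)c3)C2)n1`: > 99.9% (a limit, not a number)
- Compound 2 `CNc1nccc(N2CC[C@H](NC(=O)Nc3ccc(CN4CCCC4)c(C(F)(F)F)c3)C2)n1`: 86.5%

Compound 1 stands at the limit of > 99.9% in this assay, at which 1 of the 2 values shown sits. Compound 3 `Nc1nccc(N2CC[C@H](NC(=O)Nc3ccc(Cl)c(C(F)(F)F)c3)C2)n1` has hydrogen in place of ethyl on a nitrogen on an aromatic ring, (hydrogen in place of ethyl on a nitrogen on an aromatic ring). Among the compounds with values here, no measured pair shows this change, so the expectation remains uncertain. The limit for compound 1, > 99.9%, gives a bound and no exact starting point, and a small change is expected from it. The expected move is toward slightly lower binding, an at least 5.0-fold higher unbound fraction from compound 1 to compound 3 (0.69 log units; beyond the scatter). Compound 3 is estimated at 99.5%, with an expected range of 98.5% to 99.9%.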

Compound 3, plasma protein binding: 99.5%
Compound 3: middle estimate and measured number agree at the digits printed; the measured number falls inside the stated range.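

In this assay, within the data shown here, hydrogen in place of ethyl on a nitrogen on an aromatic ring gives an at least 5.0-fold higher unbound fraction from compound 1 to compound 3 (0.69 log units; beyond the scatter) as the first readable step at this position. Compound 1 gives > 99.9% as a limit of the assay, not a number. The step is therefore only a bound, and its true size stays unknown because the starting value is a limit: the limit of > 99.9% in this assay, at which 1 of the 3 values shown sits.

The compounds shown leave open how a longer chain or a hydroxyethyl group on that nitrogen would read in this assay. They also leave open whether the same change would give a similar step in compound 2.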